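Methoxy to methyl on the quinone ring of compound 2

The source may report more compounds than this note shows. Statements on the series, on what has been measured and on what is new or still open speak of the compounds shown alone.

Measured compounds:
compound 1 `CC1=C(CCCCCCCCCCn2cc(C[C@H](O)COCCOC[C@@H](O)Cc3ccc(-c4ccccc4)cc3)nn2)C(=O)c2ccccc2C1=O`: 390 nM
compound 2 `COC1=C(C)C(=O)C(CCCCCCCCCCn2cc(C[C@H](O)COCCOC[C@@H](O)Cc3ccc(-c4ccccc4)cc3)nn2)=C(C)C1=O`: 505 nM
compound 3 `COC1=C(OC)C(=O)C(CCCCCCCCCCn2cc(C[C@H](O)COCCOC[C@@H](O)Cc3ccc(-c4ccccc4)cc3)nn2)=C(C)C1=O`: 3800 nM

The account follows the step from compound 2 to compound 4 in a functional assay on SGC-7901 cells (Homo sapiens) for inhibition, read by MTT assay, with a stated time of 72 h; a higher number here means a weaker inhibitor of growth, a lower number a stronger inhibitor of growth. Compound 2 gives 505 nM, the second highest of the three numbers. Compound 1 gives 390 nM, and the two values lie within the scatter of each other, so nothing separates them. Among the compounds with values here, compound 3 gives 3800 nM, and the step of a 7.5-fold higher number from compound 2 to compound 3 (0.88 log units; beyond the scatter) is the only measured step that bears on the present change, since it alters the same ring carbon.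

Compound 4 `CC1=C(C)C(=O)C(CCCCCCCCCCn2cc(C[C@H](O)COCCOC[C@@H](O)Cc3ccc(-c4ccccc4)cc3)nn2)=C(C)C1=O` is the unmeasured compound. It differs from compound 2 as follows: methyl in place of methoxy on a double-bonded ring carbon. This is the reverse of the change between compound 2 and compound 3, where the methoxy entering gave a clearly higher number. Reversing that direction, the expectation is that the number falls rather than rises, though the measured step gives the magnitude in one direction only and the new compound carries three methyl groups on the ring, a pattern none of the measured compounds shows.

Compound 4 is therefore expected to give 280 nM, with a range of 110 nM to 700 nM, an expected step of a 1.8-fold lower number from compound 2 to compound 4 (0.26 log units; within the scatter).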

Compound 4, concentration for 50% growth inhibition: 350 nM
The estimate for compound 4 lay 1.3-fold (0.10 log units) below the measured number; the measured number falls inside the stated range.
By their numbers in this assay, from the lowest: compounds 4, 1 and 2 (each within the scatter of the next); then compound 3.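

In this assay, replacing the methoxy of compound 2 with methyl gives a 1.4-fold lower number from compound 2 to compound 4 (0.16 log units; within the scatter), so this ring carbon accepts either group without a change that can be told from the scatter. Within the data shown here, the earlier compounds showed only that adding a methoxy to the ring of compound 2 gives a 7.5-fold higher number from compound 2 to compound 3 (0.88 log units; beyond the scatter), and that step alters a different ring carbon, the one bearing a methyl group in compound 2. The two steps are therefore not mirror images: among these three quinones, removing the one methoxy leaves the number where it was, and only compound 3, with two methoxy groups, stands apart at 3800 nM; nothing available explains this difference between the steps.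

As far as these compounds go, whether an ethoxy group, a hydroxyl group or a chlorine atom on this ring carbon would stay with compound 2 and compound 4 or move towards compound 3 remains open. Also open, from the compounds shown here alone, is whether the same indifference to methoxy or methyl would hold with a shorter or longer chain joining the quinone ring to the triazole.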